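The source may report more compounds than this note shows. Statements on the series, on what has been measured and on what is new or still open speak of the compounds shown alone.

Measured compounds:
compound 1, `C=CCOc1ccc(C(=O)Nc2ccccn2)cc1`: 61400 nM
compound 2, `CCCOc1ccc(C(=O)Nc2cccc(C)n2)cc1`: 11100 nM
compound 3, `CCCOc1ccc(C(=O)Nc2cccc(Nc3ccc(F)cc3)n2)cc1`: a limit, > 100000 nM

All three were tested in an in vitro assay on HEK-tsA201 cells for antagonist activity at Neuronal acetylcholine receptor; alpha3/beta4 (Homo sapiens), read by fluorescence and calcium flux; on this read-out higher numbers stand for weaker inhibition and lower numbers for stronger inhibition. Compound 1 stands highest of the two numbers, with compound 2 giving the nearest number. Compound 3 gives only a limit; the measurement reports the limit of > 100000 nM in this assay, at which 1 of the 3 values shown sits, rather than a number. The unmeasured compound 4, `C=CCOc1ccc(C(=O)Nc2cccc(NCCCC)n2)cc1`, differs from compound 1 in one place: butylamino in place of hydrogen on an aromatic carbon. For the measured compounds named here, only one measured step bears on this change, the one in which an amino-linked group entered at the same place on the core of compound 2: an at least 9.0-fold higher number from compound 2 to compound 3 (0.95 log units; beyond the scatter). Compound 1 already gives a high number in this assay, so a step of similar direction would carry compound 4 past the range the assay reports. Compound 4 is therefore expected to give a weaker result than compound 1, estimated as a 2.0-fold higher number from compound 1 to compound 4 (0.29 log units; within the scatter). The estimate for compound 4 is 120000 nM, within 40000 nM to 400000 nM, with a real chance that only a limit is reported.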

Compound 4, half-maximal inhibitory concentration: 19200 nM
Compound 4: middle estimate off by 6.3-fold (0.80 log units), on the high side; the whole stated range lies above it.
By their numbers in this assay, from the lowest: compounds 2 and 4 (each within the scatter of the next); then compound 1. At a limit, above all of these: compound 3.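

In this assay the place next to the ring nitrogen accepts a chain and inhibition gets stronger, as butylamino in place of hydrogen shows (a 3.2-fold lower number from compound 1 to compound 4 (0.50 log units; beyond the scatter)). The earlier step at this place ran the opposite way (an at least 9.0-fold higher number from compound 2 to compound 3 (0.95 log units; beyond the scatter)), so an amino link here does not by itself fix the direction of change. Compound 3 gives only a limit, not a number: the limit of > 100000 nM in this assay, at which 1 of the 4 values shown sits.

Going by these compounds, whether the gain belongs to the butyl chain or to the amino nitrogen stays open, and a plain amino group, a shorter propylamino chain or a pentyl chain without the nitrogen at this place would separate the two. Also open, on these data alone, is whether butylamino would give a similar step on a core carrying propoxy in place of allyloxy.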